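The source may report more compounds than this note shows. Statements on the series, on what has been measured and on what is new or still open speak of the compounds shown alone.

Three compounds have been measured so far:

compound 1, `O=C(c1ccccc1)c1sc(N2CCCC2)nc1Br`, 97000 nM
compound 2, `O=C(c1ccccc1)c1sc(N2CCCCC2)nc1Br`, 48000 nM
compound 3, `COC(=O)c1sc2nc(N3CCCC3)sc2c1C`, 86000 nM

All three were tested in a functional assay on A549 cells (Homo sapiens) for cytotoxicity, read by MTT assay, with a stated time of 72 h; a higher number here means a weaker inhibitor, a lower number a stronger inhibitor. Compound 1 and compound 2 share one core and differ in a single place: piperidin-1-yl in place of pyrrolidin-1-yl on an aromatic carbon. That change gave a 2.0-fold lower number from compound 1 to compound 2 (0.31 log units; beyond the scatter). Compound 3 is built on another core, and the difference between the two cores of compound 1 and compound 3 is not broken down here. Compound 4, `COC(=O)c1sc2nc(N3CCCCC3)sc2c1C`, has not yet been measured. It stands to compound 3 as compound 2 stands to compound 1, through the same kind of change: piperidin-1-yl in place of pyrrolidin-1-yl on an aromatic carbon. The surroundings of the place are not identical in the two cases. In compound 1 the carbon that carries the group is two ring bonds from the ring atom that bears a bromo group and two ring bonds from the ring atom that bears a group of 8 heavy atoms, whereas in compound 3 the ring that carries the group is part of a fused or bridged system of two rings. Among the measured compounds shown here, only one earlier example of this change exists, so the expectation rests on a single step. Compound 4 is expected to follow it, with an estimated step of a 1.9-fold lower number from compound 3 to compound 4 (0.28 log units; within the scatter), because the same change gave a 2.0-fold lower number from compound 1 to compound 2 (0.31 log units; beyond the scatter). Compound 4 is therefore expected to give 45000 nM in this assay, with a range from 20000 nM to 110000 nM allowing for the different core.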

Compound 4, half-maximal inhibitory concentration: > 100000 nM
Compound 4 gave a limit, no number; the forecaster's own chance of this, stated with the estimate: 10%; middle value at least 2.2-fold (0.34 log units) from the limit.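

In this assay compound 4 gives > 100000 nM, which is a limit of the assay and not a number. The swap of pyrrolidin-1-yl for piperidin-1-yl on this core can therefore be read only as a floor, an at least 1.1-fold higher number from compound 3 to compound 4 (0.06 log units; that floor lies within the scatter), so compound 4 gives no sign of the lower number that the same change produced on the core of compound 1. This does not show that the change behaves differently on the two cores, nor that it behaves alike, and each core offers only a single pair to judge from: the same change on two cores in this assay, a 2.0-fold lower number (0.31 log units; beyond the scatter) from compound 1 to compound 2 and an at least 1.1-fold higher number (0.06 log units; that floor lies within the scatter) from compound 3 to compound 4; the limit leaves it open whether they differ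

The compounds shown carry only pyrrolidin-1-yl and piperidin-1-yl at this place, which leaves open whether a morpholine ring or an open-chain amine such as dimethylamino would shift the number on either core. Also open is how far the true value of compound 4 lies from the limit, and with it the real size of the step on this core: the limit of > 100000 nM in this assay, at which 1 of the 4 values shown sits.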